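Side-chain exchange from compound 3 to compound 4

The source may report more compounds than this note shows. Statements on the series, on what has been measured and on what is new or still open speak of the compounds shown alone.

Measured in an ADME assay for permeability, using PAMPA (a higher number here means that the compound crosses the layer faster, a lower number that the compound crosses the layer more slowly), so far
- compound 1 `COc1cc(N2CCC(CC(=O)N3CCOCC3)CC2)ccc1Nc1nc(NC2CCCCC2)c2nc[nH]c2n1` gives 409 10^-6 cm/s
- compound 2 `COc1cc(N2CCC(CC(=O)N3CCN(C)CC3)CC2)ccc1Nc1nc(NC2CCCCC2)c2nc[nH]c2n1` gives 530 10^-6 cm/s
- compound 3 `CCN(CC)CC1CCN(c2ccc(Nc3nc(NC4CCCCC4)c4nc[nH]c4n3)c(OC)c2)CC1` gives 480 10^-6 cm/s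

Compound 3 cannot be told apart from the other two measured compounds, as all three values lie within the scatter of one another. Compound 4 `COc1cc(N2CCC(CC(=O)N3CCC(N(C)C)C3)CC2)ccc1Nc1nc(NC2CCCCC2)c2nc[nH]c2n1` has not yet been measured. Its difference from compound 3 is as follows: (3-(dimethylamino)pyrrolidin-1-yl)carbonyl in place of diethylamino on a saturated chain carbon bound to a saturated ring carbon (in words, (3-(dimethylamino)pyrrolidin-1-yl)carbonyl in place of diethylamino on a saturated chain carbon bound to a saturated ring carbon).

Two measured steps are the closest precedents, and both run in the reverse sense, from a carbonyl group to diethylamino. With (morpholin-4-yl)carbonyl leaving, the step is small (a 1.2-fold higher number from compound 1 to compound 3 (0.07 log units; within the scatter)). With (4-methylpiperazin-1-yl)carbonyl leaving, it is also small (a 1.1-fold lower number from compound 2 to compound 3 (0.04 log units; within the scatter)). Exchanging the group on the carbonyl carbon gives a third small step (a 1.3-fold higher number from compound 1 to compound 2 (0.11 log units; within the scatter)). Among the compounds with values here, no compound carrying 3-(dimethylamino)pyrrolidin-1-yl has been measured, so the range stays wide. On the strength of these three steps, no change beyond the scatter is expected in this assay. The expected step is small (a 1.0-fold lower number from compound 3 to compound 4 (0.01 log units; within the scatter)). For compound 4 the estimated value is 470 10^-6 cm/s, with an expected range from 280 10^-6 cm/s to 750 10^-6 cm/s.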

Compound 4, apparent permeability: "impermeable" (no number reported)
For compound 4 the study gives words and no number; no gap can be computed for the estimate.
By their numbers in this assay, from the lowest: compounds 1, 3 and 2 (each within the scatter of the next).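

In this assay, within the data shown here, compound 4 is reported only in words, as "impermeable", so no step linking it to compound 1, compound 2 or compound 3 can be read. No available evidence bears on this result. The compounds shown leave open how far compound 4 lies from the other three, and whether (3-(dimethylamino)pyrrolidin-1-yl)carbonyl alone accounts for that report.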